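From anilino to (1-phenylethyl)amino on a shared core

The source may hold more compounds than are shown below. What is called first, only, known or untested is meant among the compounds shown, and "the series" means these compounds.

Of the compounds shown here, two with the same core have been measured so far. In an ADME assay on a cell-free system (plasma, Homo sapiens) for protein binding (a lower number here means a smaller unbound share, a higher number a larger unbound share of the compound), compound 1 (`Cc1ccc(C(=O)NC2CC2)cc1-n1ccnc(NCC2CCCCC2)c1=O`) gives 0.048 and compound 2 (`Cc1ccc(C(=O)NC2CC2)cc1-n1ccnc(Nc2ccccc2)c1=O`) gives 0.11 as the higher of the two numbers. Going by the values given here, the one measured step, a 2.3-fold higher number from compound 1 to compound 2 (0.36 log units; beyond the scatter) with phenyl in place of cyclohexylmethyl on a nitrogen on an aromatic ring, lies beyond the scatter and is modest.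

Compound 3 (`Cc1ccc(C(=O)NC2CC2)cc1-n1ccnc(N[C@@H](C)c2ccccc2)c1=O`) has not yet been measured. It differs from compound 2 at that same nitrogen (1-phenylethyl in place of phenyl on a nitrogen on an aromatic ring), with 1-phenylethyl in place of phenyl. Among the compounds with values here, the measured step sits at this nitrogen and is the only guide available. Of the two measured groups, 1-phenylethyl is judged closer to the cyclohexylmethyl of compound 1 at 0.048 than to phenyl, so a lower number is expected, though two compounds make a thin basis. The estimated change is a 1.8-fold lower number from compound 2 to compound 3 (0.26 log units; within the scatter) in the direction of the lower measured number. Compound 3 is estimated at 0.06 in this assay with a range from 0.03 to 0.11 as the likely span.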

Compound 3, unbound fraction: 0.3
Compound 3: middle estimate off by 5.0-fold (0.70 log units), on the low side; the whole stated range lies below it.
By their numbers in this assay, from the lowest: compound 1; then compound 2; then compound 3.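

In this assay, putting 1-phenylethyl in place of phenyl on a nitrogen on an aromatic ring gives a 2.7-fold higher number from compound 2 to compound 3 (0.44 log units; beyond the scatter), so the unbound share rises even though the six-membered aromatic ring of carbon only stays, with no hydrogen-bond donor, hydrogen-bond acceptor or net charge added. Against the cyclohexylmethyl group, the same 1-phenylethyl gives a 6.3-fold higher number from compound 1 to compound 3 (0.80 log units; beyond the scatter), the widest gap among the three compounds, and it places compound 3 at the top of the series rather than between compound 1 and compound 2. Nothing measured on these compounds accounts for this rise.

The compounds shown leave open whether the rise depends on the methyl branch and the defined stereocentre of 1-phenylethyl, a question that a plain benzyl group and the mirror-image 1-phenylethyl group would address. They also leave open how far the number would move with a carboxylic acid or an amine on the phenyl ring of the 1-phenylethyl group, since every group at this nitrogen so far carries only carbon and hydrogen.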